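The compounds below may be only part of what the source reports. "The series", "measured", "known", "first", "only" and "open" are said of these compounds alone.

Compound 2 `CCn1c(C(=O)N(C)c2ccccc2)ccc1C(CC)(CC)c1ccc(OCC(O)C(C)(C)C)c(C)c1` carries a methyl(phenyl)carbamoyl group on its core. In an assay on HL-60 cells for agonist activity at vitamin D3 receptor (Homo sapiens), read by microscopy, with a stated time of 96 h (a higher number here means that more compound is needed for the effect, a lower number that less compound is needed), compound 2 gives 6400 nM, the highest of the two numbers shown so far. Its nearest neighbour, compound 1 `C=CCN(C)C(=O)c1ccc(C(CC)(CC)c2ccc(OCC(O)C(C)(C)C)c(C)c2)n1CC`, gives 3950 nM in this assay. Among the compounds with values here, the only measured step is a 1.6-fold higher number from compound 1 to compound 2 (0.21 log units; within the scatter), and it lies within the scatter, so the two compounds cannot be told apart. Compound 3 `C#CCCOC(=O)c1ccc(C(CC)(CC)c2ccc(OCC(O)C(C)(C)C)c(C)c2)n1CC` differs from compound 2 by (but-3-yn-1-yl)oxy in place of methyl(phenyl)amino on a carbonyl carbon; the carbonyl thus becomes part of an ester rather than an amide. Within the data shown here, the one measured step swapped a group on the amide nitrogen and changed little, and no measured pair exchanges the amide itself, so there is no basis for a shift in either direction. A step of a 1.3-fold lower number from compound 2 to compound 3 (0.11 log units; within the scatter) is therefore expected, with wide uncertainty. Compound 3 is estimated at 5000 nM, in a range from 1500 nM to 17000 nM.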

Compound 3, half-maximal effective concentration: 1030 nM
Beside the measured number, compound 3's estimate is 4.9-fold (0.69 log units) above it, and the stated range ends above it.
By their numbers in this assay, from the lowest: compound 3; then compounds 1 and 2 (each within the scatter of the next).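

The earlier compounds shown here varied only a group on the amide nitrogen, a change that stayed within the scatter, so they gave no sign that this carbonyl carbon could respond to substitution. Replacing the whole methyl(phenyl)amino group with (but-3-yn-1-yl)oxy turns the amide into an ester and gives, in this assay, a 6.2-fold lower number from compound 2 to compound 3 (0.79 log units; beyond the scatter) as a step beyond the scatter. The matching change from the allyl(methyl)amino amide gives a 3.8-fold lower number from compound 1 to compound 3 (0.58 log units; beyond the scatter) and points the same way, so less compound is needed with this ester than with either amide, although both steps are modest.

Going by these compounds, whether this follows from the ester link itself or from the but-3-yn-1-yl chain remains open, as does what an ethoxy group, a carboxylic acid or a longer chain would give on this carbonyl carbon. Nothing available here explains why the ester gives the lower number.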